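From compound 1 to compound 4: hydroxyl in place of bromine

A few compounds are considered here, and "the series" means these few. Any claim that something is new, unique, unknown or untested is made for them only; others in the source may bear on it.

Compound 1 `O=C(N/N=C/c1cccc(Br)c1)Nc1ccc(Oc2ccnc3[nH]ccc23)c(F)c1`: 4020 nM
Compound 2 `O=C(N/N=C/c1cccc(Cl)c1Cl)Nc1ccc(Oc2ccnc3[nH]ccc23)c(F)c1`: "not active" (no number reported)
Compound 3 `O=C(N/N=C/c1ccc(Cl)c(Cl)c1)Nc1ccc(Oc2ccnc3[nH]ccc23)c(F)c1`: 14100 nM

In a functional assay on PC-3 cells (Homo sapiens) for antiproliferative activity, read by MTT assay, with a stated time of 72 h (a higher number here means a weaker inhibitor, a lower number a stronger inhibitor), compound 1 gives the lowest of the two reported numbers; compound 3 lies a 3.5-fold higher number from compound 1 to compound 3 (0.54 log units; beyond the scatter) away, and compound 2 gave no number at all in this assay. Compound 4 `O=C(N/N=C/c1ccc(O)cc1)Nc1ccc(Oc2ccnc3[nH]ccc23)c(F)c1` has not been measured. It differs from compound 1 by 4-hydroxyphenyl in place of 3-bromophenyl on a carbon with a double bond to nitrogen. Going by the values given here, no measured step covers this change: the one step in hand, from compound 1 to compound 3, only shows that altering the substituents on that ring shifts the number modestly. A step of similar size is therefore expected, with no direction fixed, so the estimate for compound 4 is 6000 nM, within 1500 nM to 25000 nM, a step of a 1.5-fold higher number from compound 1 to compound 4 (0.17 log units; within the scatter).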

Compound 4, half-maximal inhibitory concentration: 2780 nM
Beside the measured number, compound 4's estimate is 2.2-fold (0.33 log units) above it; the measured number falls inside the stated range.
By their numbers in this assay, from the lowest: compounds 4 and 1 (each within the scatter of the next); then compound 3.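

In this assay, 4-hydroxyphenyl on a carbon with a double bond to nitrogen reads level with 3-bromophenyl (a 1.4-fold lower number from compound 1 to compound 4 (0.16 log units; within the scatter)), so this place tolerates a ring carrying a hydrogen-bond donor and acceptor. Set against 3,4-dichlorophenyl, the same group gives a 5.1-fold lower number from compound 3 to compound 4 (0.71 log units; beyond the scatter). No measurement at hand explains either step. Still open, on these data alone, is whether the hydroxyl itself or its place on the ring decides the reading, and how an amine or a carboxylic acid on that ring would fare in this assay.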